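The source may hold more compounds than are shown below. What is called first, only, known or untested is meant among the compounds shown, and "the series" means these compounds.

Compound 1 `CC1NC(NC[C@H]2CCCO2)=Nc2ccccc21`: 163 nM
Compound 2 `CC1NC(NCC2COCCO2)=Nc2ccccc21`: 96 nM
Compound 3 `CNC1=Nc2ccccc2C(C)N1`: 103 nM

In an assay on isolated protein for binding affinity to 5-hydroxytryptamine receptor 5A (Homo sapiens) (a lower number here means a stronger inhibitor, a higher number a weaker inhibitor), compound 3 holds the second highest of the three numbers. Its nearest neighbour is compound 2, with a 1.1-fold higher number from compound 2 to compound 3 (0.03 log units; within the scatter); its furthest is compound 1, with a 1.6-fold lower number from compound 1 to compound 3 (0.20 log units; within the scatter). Compound 4 `CCCNC1=Nc2ccccc2C(C)N1` differs from compound 3 by ethyl in place of hydrogen on a saturated chain carbon bound to an amine nitrogen. Every measured step touches the same place: oxolan-2-yl against hydrogen gave a 1.6-fold lower number from compound 1 to compound 3 (0.20 log units; within the scatter), 1,4-dioxan-2-yl against hydrogen gave a 1.1-fold higher number from compound 2 to compound 3 (0.03 log units; within the scatter), and one ring against the other gave a 1.7-fold lower number from compound 1 to compound 2 (0.23 log units; within the scatter), none beyond the scatter. Since far larger groups at this carbon left this assay unmoved, an ethyl is expected to do the same, giving a 1.1-fold higher number from compound 3 to compound 4 (0.03 log units; within the scatter). Compound 4 is therefore estimated at 110 nM, between 50 nM and 240 nM.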

Compound 4, inhibition constant: 153 nM
Beside the measured number, compound 4's estimate is 1.4-fold (0.14 log units) below it, within the range that was stated.
By their numbers in this assay, from the lowest: compounds 2, 3, 4 and 1 (each within the scatter of the next).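

At the saturated chain carbon bound to an amine nitrogen, an ethyl with no ring now stands alongside hydrogen and both ring groups in this assay, with a 1.5-fold higher number from compound 3 to compound 4 (0.17 log units; within the scatter) and a 1.6-fold higher number from compound 2 to compound 4 (0.20 log units; within the scatter) and also a 1.1-fold lower number from compound 1 to compound 4 (0.03 log units; within the scatter). The earlier compounds shown here showed this flat reading only for the two ring groups against hydrogen, and it now extends to a plain alkyl group. No evidence is available to explain this reading.

The compounds shown leave open whether a carboxylic acid, an amine or a phenyl ring at this carbon would also stay within the scatter in this assay. They also leave open whether changes elsewhere on the shared core would read as flatly.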